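From phenyl to 3-fluorophenyl on compound 2

The compounds below may be only part of what the source reports. "The series", "measured", "known", "first", "only" and "open" are said of these compounds alone.

For the measured compounds named here, three related compounds have so far gone into an ADME assay on brain (Rattus norvegicus) for protein binding (a higher number here means a larger unbound share of the compound, a lower number a smaller unbound share), and only one returned a number. There compound 1 `N#Cc1ccccc1COc1ccc([C@H]2CC[C@@H](C(N)=O)N2)cc1` gives a single value (0.063). Compound 2 `NC(=O)[C@@H]1CC[C@H](c2ccc(OCc3ccccc3)cc2)N1` has no single number ("not determined" (no result reported)), so it has no place on the scale yet. Compound 3 `NC(=O)[C@@H]1CC[C@H](c2ccc(Oc3ccccc3)cc2)N1` is in the same position ("not determined" (no result reported)).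

Compound 4 `NC(=O)[C@@H]1CC[C@H](c2ccc(OCc3cccc(F)c3)cc2)N1` is compound 2 with one change (fluoro in place of hydrogen on an aromatic carbon), fluoro in place of hydrogen on an aromatic carbon, meta to a large group. Going by the values given here, no measured step exists to size this change. The expectation in this assay is therefore of no shift beyond the usual scatter, in either direction, from wherever compound 2 would sit. Among the compounds with values here, the only number to lean on is that of compound 1 (0.063), and the estimate stays close to it. The unbound fraction expected for compound 4 is 0.05 (estimated range 0.02 to 0.11).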

Compound 4, unbound fraction: 0.01
For compound 4 the middle estimate is 5.0-fold (0.70 log units) above the measured one, and the stated range ends above it.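

this assay now holds its first measured step, and it lies at the benzyl end of the molecule: 3-fluorophenyl in place of 2-cyanophenyl gives a 6.3-fold lower number from compound 1 to compound 4 (0.80 log units; beyond the scatter) on the saturated chain carbon bound to an oxygen on an aromatic ring. For the compounds shown here, this shows that the substituted phenyl at this position can move the unbound share beyond the scatter, which the single value of compound 1 could not show. The step swaps two different groups at once, so it cannot be credited to the fluoro or to the loss of the nitrile, and nothing available accounts for it.

On these data alone, the step from compound 2 to compound 4 cannot be read, so the size of the change from phenyl to 3-fluorophenyl stays open. Also open, as far as these compounds go, is how a carboxylic acid or an amine on this phenyl ring would compare with compound 4.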